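Cyclopropylidene purine series: octylsulfanyl analogue, cytotoxicity outlook

This account rests on a few compounds, and the source may have more. Where it says the series, first, only, none or still open, it means among the compounds named here.

Compound 1 `CCCOc1nc(N)nc2c1ncn2/C=C1/CC1(CO)CO` and compound 2 `CCCCNc1nc(N)nc2c1ncn2/C=C1/CC1(CO)CO` share one core and differ only at an aromatic carbon. In an ADME assay on HFF cells (Homo sapiens) for cytotoxicity, with a stated time of 8 days (a lower number here means that less compound is tolerated, a higher number that more compound is tolerated), compound 1 gives > 300000 nM, which is a limit of the assay and not a number. In this assay compound 2 likewise gives > 300000 nM, again a limit. The step that the two limits leave unreadable from compound 1 to compound 2 cannot be read as a size for that reason; the evidence is the limit of > 300000 nM in this assay, at which 2 of the 2 values shown sit, so compound 2 stands at the top of what this assay can report.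

Compound 3 `CCCCCCCCSc1nc(N)nc2c1ncn2/C=C1/CC1(CO)CO` is the next change: octylsulfanyl in place of butylamino on an aromatic carbon. Among the measured compounds shown here, no measured step speaks to this exchange, since the only step, from propoxy to butylamino, is unreadable between two limits. No movement beyond the scatter is expected in this assay; compound 3 is estimated at 250000 nM, between 60000 nM and 400000 nM, which is an expected step of an at least 1.2-fold lower number from compound 2 to compound 3 (0.07 log units; that floor lies within the scatter).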

Compound 3, half-maximal cytotoxic concentration: > 300000 nM
Compound 3: a limit, no number; the forecaster's own chance of this, stated with the estimate: 45%; at least 1.2-fold (0.07 log units) between middle value and limit.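

In this assay no step can be read among compound 1, compound 2 and compound 3, since all three values are limits and not numbers: the limit of > 300000 nM in this assay, at which 3 of the 3 values shown sit.

The compounds shown leave open whether any group on this aromatic carbon gives a readable half-maximal cytotoxic concentration.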